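Swapping the aryl group on a sulfonamide nitrogen

A few compounds are considered here, and "the series" means these few. Any claim that something is new, unique, unknown or untested is made for them only; others in the source may bear on it.

Compound 1 `Cc1ccc(NS(=O)(=O)c2ccc(N3CCNC3=O)cc2)cc1C`: 230 nM
Compound 2 `O=C1NCCN1c1ccc(S(=O)(=O)Nc2ccc(Br)cc2)cc1`: 300 nM

In a functional assay on HT-29 cells (Homo sapiens) for antiproliferative activity, read by sulforhodamine B assay, with a stated time of 48 h (a higher number here means a weaker inhibitor, a lower number a stronger inhibitor), compound 2 gives 300 nM, within the scatter of compound 1 at 230 nM. Compound 3 `Cc1cccc(NS(=O)(=O)c2ccc(N3CCNC3=O)cc2)c1C` has 2,3-dimethylphenyl in place of 4-bromophenyl on a sulfonamide nitrogen. Within the data shown here, one measured step bears on this: a 1.3-fold higher number from compound 1 to compound 2 (0.12 log units; within the scatter), a similar swap that stayed within the scatter. Among the measured compounds shown here, no measurement yet compares 2,3-dimethylphenyl with 3,4-dimethylphenyl, so the range stays wide. In this assay the expected step is no change at the digits printed from compound 2 to compound 3 (within the scatter), with no change expected beyond the scatter. For compound 3 the estimated value is 300 nM, with an expected range of 100 nM to 900 nM.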

Compound 3, half-maximal inhibitory concentration: 190 nM
Beside the measured number, compound 3's estimate is 1.6-fold (0.20 log units) above it, within the range that was stated.
By their numbers in this assay, from the lowest: compounds 3, 1 and 2 (each within the scatter of the next).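

In this assay, 2,3-dimethylphenyl in place of 3,4-dimethylphenyl on the sulfonamide nitrogen stays within the scatter (a 1.2-fold lower number from compound 1 to compound 3 (0.08 log units; within the scatter)). The same holds for 2,3-dimethylphenyl in place of 4-bromophenyl (a 1.6-fold lower number from compound 2 to compound 3 (0.20 log units; within the scatter)), so these three aryl groups cannot be told apart in this assay. No evidence is available to explain this result. Still open, as far as these compounds go, is whether a phenyl ring carrying a carboxylic acid or an amine, or a longer chain in place of the ring, would move the number beyond the scatter.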